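Chloro for methyl on a phenoxy ring in cytotoxicity

This account rests on a few compounds, and the source may have more. Where it says the series, first, only, none or still open, it means among the compounds named here.

The measured compounds and their values are:
compound 1 `Cc1ccc(-c2csc(NC(=O)COc3ccc(F)cc3)n2)cc1` 19100 nM
compound 2 `O=C(COc1ccc(F)cc1)Nc1nc(-c2ccc(Cl)cc2)cs1` 36300 nM
compound 3 `Cc1ccc(OCC(=O)Nc2nc(-c3ccc(C)cc3)cs2)cc1` 48800 nM

These three share a core in which the two aromatic rings are joined through an amide and an ether. In a functional assay on A549 cells (Homo sapiens) for cytotoxicity, read by trypan blue exclusion, with a stated time of 48 h (a lower number here means a stronger inhibitor, a higher number a weaker inhibitor), compound 1 gives 19100 nM and compound 3 gives 48800 nM; the difference between their cores is methyl in place of fluoro on an aromatic carbon. Compound 2 differs from compound 1 by chloro in place of methyl on an aromatic carbon, and that change gave a 1.9-fold higher number from compound 1 to compound 2 (0.28 log units; within the scatter).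

Compound 4 `Cc1ccc(-c2csc(NC(=O)COc3ccc(Cl)cc3)n2)cc1` has not been measured. It differs from compound 3 by chloro in place of methyl on an aromatic carbon, the same change in kind as from compound 1 to compound 2, at a place described in the same words, though the further reading names a phenoxy rather than a phenyl. On that single precedent, the step from compound 3 to compound 4 is expected to be about a 1.5-fold higher number from compound 3 to compound 4 (0.19 log units; within the scatter), a number of a similar size because a 1.9-fold higher number from compound 1 to compound 2 (0.28 log units; within the scatter) was small. Compound 4 is therefore estimated at 75000 nM in this assay, between 30000 nM and 180000 nM.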

Compound 4, half-maximal inhibitory concentration: 44700 nM
Beside the measured number, compound 4's estimate is 1.7-fold (0.22 log units) above it; the range from low to high includes it.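

In this assay, chloro in place of methyl gave a 1.1-fold lower number from compound 3 to compound 4 (0.04 log units; within the scatter), and the same change on the other core was also a step within the scatter. Set side by side, the two steps do not differ: the same change on two cores in this assay, a 1.9-fold higher number (0.28 log units; within the scatter) from compound 1 to compound 2 and a 1.1-fold lower number (0.04 log units; within the scatter) from compound 3 to compound 4, 2.1-fold (0.32 log units) apart, within the scatter of two such steps. For the compounds shown here, this shows that the change carried over between these two cores without a detectable difference, but with only two pairs, each within the scatter, it does not show that the change itself moves the number in this assay or that the agreement would hold on a further core.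

Chloro in place of fluoro gave a 2.3-fold higher number from compound 1 to compound 4 (0.37 log units; beyond the scatter), a modest step that rests on this single pair, so the compounds shown leave open whether it would recur on another core. They also leave open how this series would respond if an amine, a carboxylic acid or a methoxy group stood in place of the chloro, methyl or fluoro groups on these aromatic rings.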